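Benzyl for ethyl on the amine of a coumarin amide

The source may hold more compounds than are shown below. What is called first, only, known or untested is meant among the compounds shown, and "the series" means these compounds.

Compound 1 `CCN(C)CCCOc1ccc2cc(NC(=O)c3ccc(O)c(CC=C(C)C)c3)c(=O)oc2c1C` is the reference point of this small set. In a functional assay on MCF7 cells (Homo sapiens) for antiproliferative activity (on this read-out lower numbers stand for stronger inhibition and higher numbers for weaker inhibition), compound 1 gives 2190 nM, the highest number among the three measured compounds. Compound 2 `CCCNCCCOc1ccc2cc(NC(=O)c3ccc(O)c(CC=C(C)C)c3)c(=O)oc2c1C` gives 980 nM, and compound 3 `CC(C)=CCc1cc(C(=O)Nc2cc3ccc(OCCCN(C)C4CCCCC4)c(C)c3oc2=O)ccc1O` gives 1080 nM. The two measured steps leading away from compound 1 are both modest: a 2.2-fold lower number from compound 1 to compound 2 (0.35 log units; beyond the scatter), and a 2.0-fold lower number from compound 1 to compound 3 (0.31 log units; beyond the scatter). Between the two lower-numbered compounds there is no real difference, as a 1.1-fold higher number from compound 2 to compound 3 (0.04 log units; within the scatter).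

Compound 4 `CC(C)=CCc1cc(C(=O)Nc2cc3ccc(OCCCN(C)Cc4ccccc4)c(C)c3oc2=O)ccc1O` differs from compound 1 by the change (phenyl in place of methyl on a saturated chain carbon bound to an amine nitrogen). Within the data shown here, the step that bears most on it is the one to compound 3, where cyclohexyl replaced ethyl on the amine nitrogen and the number fell modestly a 2.0-fold lower number from compound 1 to compound 3 (0.31 log units; beyond the scatter). Among the measured compounds shown here, the benzyl(methyl)amino group of compound 4 likewise carries a larger ring-bearing substituent on the nitrogen, so a lowering of similar size is the natural expectation; the step to compound 2 a 2.2-fold lower number from compound 1 to compound 2 (0.35 log units; beyond the scatter) points the same way, though no measured compound carries an aromatic ring at this place. Compound 4 is therefore expected to show a 2.0-fold lower number from compound 1 to compound 4 (0.30 log units; within the scatter). Compound 4 is estimated at 1100 nM, within a range of 500 nM to 2500 nM.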

Compound 4, half-maximal inhibitory concentration: 11500 nM
Estimate against measurement, compound 4: 10-fold (1.02 log units) below, and the stated range ends below it.
By their numbers in this assay, from the lowest: compounds 2 and 3 (each within the scatter of the next); then compound 1; then compound 4.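

In this assay the amine nitrogen does not simply reward a larger substituent: benzyl in place of ethyl gives a 5.3-fold higher number from compound 1 to compound 4 (0.72 log units; beyond the scatter) and so runs opposite to both earlier steps away from compound 1. Carrying a ring on the nitrogen does not by itself preserve the lower number of compound 3, as benzyl in place of cyclohexyl gives an 11-fold higher number from compound 3 to compound 4 (1.03 log units; beyond the scatter) in this large step. The comparison with the secondary amine agrees, with a 12-fold higher number from compound 2 to compound 4 (1.07 log units; beyond the scatter) as a second large step, so that propylamino and cyclohexyl(methyl)amino sit within the scatter of each other while benzyl(methyl)amino stands clearly apart from both.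

On these data alone, whether the rise belongs to the phenyl ring itself or to its placement on the saturated chain carbon bound to the amine nitrogen stays open, and a phenethyl or a pyridylmethyl group on that nitrogen would bear on this. As far as these compounds go, it also remains open whether the methyl kept on the nitrogen matters, which a benzylamino group would test.

No supporting measurement is available to explain the rise in the number.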